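Swapping the oxime ether from E to Z: what to expect

The source may report more compounds than this note shows. Statements on the series, on what has been measured and on what is new or still open speak of the compounds shown alone.

Compound 2, `CC/C(=N\OC)c1ccccc1NCC1=NCCN1`, carries an oxime ether chain on the shared core. In a functional assay for activation of Alpha-1D adrenergic receptor (Homo sapiens) (on this read-out lower numbers stand for an effect already at smaller amounts and higher numbers for an effect only at larger amounts of compound), compound 2 gives < 100000 nM, which is a limit of the assay and not a measured number. Among the compounds with values here, the only other measured compound, compound 1 with structure `Cc1nc(-c2ccccc2NCC2=NCCN2)co1`, differs from compound 2 by a group of 6 heavy atoms (4 carbon, 1 nitrogen, 1 oxygen; one five-membered aromatic ring with 2 hetero atoms) on an aromatic carbon in place of the open chain. In this assay compound 1 gives < 5020 nM, likewise a limit. The step that the two limits leave unreadable from compound 1 to compound 2 therefore cannot be read in size, as the two limits the limit of < 100000 nM in this assay, at which 1 of the 2 values shown sits, and the limit of < 5020 nM in this assay, at which 1 of the 2 values shown sits, show.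

Compound 3, `CC/C(=N/OC)c1ccccc1NCC1=NCCN1`, is the subject here. Its change from compound 2 is the two compounds have the same atoms and bonds and differ only in configuration as drawn: 1 of 1 stereo elements differ; a double bond is drawn E in compound 2 and Z in compound 3. Within the data shown here, no measured step bears on a change of this kind, so no direction can be taken from the data. The estimated step that the limit leaves unreadable from compound 2 to compound 3 is set to none beyond the scatter, and compound 3 is expected to give about 3000 nM, within 200 nM to 40000 nM.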

Compound 3, half-maximal effective concentration: < 5020 nM
Compound 3: only a limit was reported; the forecaster's own chance of this, stated with the estimate: 50%; the middle value lies beyond the limit too.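

Compound 3, like compound 1 and compound 2, gives only a limit of the assay, so no step among these three compounds can be read in size: the limit of < 5020 nM in this assay, at which 2 of the 3 values shown sit.

Going by these compounds, whether the change from E in compound 2 to Z in compound 3 alters the effect in this assay stays open, and so does how the open chain compares with the ring group of compound 1.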